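A few compounds are considered here, and "the series" means these few. Any claim that something is new, unique, unknown or untested is made for them only; others in the source may bear on it.

Measured in a functional assay on HepG2 cells (Homo sapiens) for cytotoxicity, read by MTT assay, with a stated time of 48 h (on this read-out lower numbers stand for stronger inhibition and higher numbers for weaker inhibition), so far
- compound 1 `CC1=NN(C(=O)COc2ccc(Cl)cc2)C(c2ccccc2O)C1` gives "not active" (no number reported)
- compound 2 `CC1=NN(C(=O)c2ccc(C)cc2)C(c2cc(Br)ccc2O)C1` gives 23200 nM
- compound 3 `CC1=NN(C(=O)COc2ccc(Cl)cc2)C(c2cc(Br)ccc2O)C1` gives "not active" (no number reported)

Compound 1 has no single number and shares that standing with compound 3, so compound 2 alone provides a figure. The next compound is compound 4 `CC1=NN(C(=O)CN2CCCCC2)C(c2ccccc2O)C1`, with piperidin-1-yl in place of 4-chlorophenoxy on a saturated chain carbon bound to a carbonyl carbon as the change: piperidin-1-yl in place of 4-chlorophenoxy on a saturated chain carbon bound to a carbonyl carbon. No measured step sizes this change. Within the data shown here, a modest step toward stronger inhibition is expected in this assay, reaching at best the weak range set by compound 2 at 23200 nM as the sole number. The estimated value for compound 4 is 40000 nM with an expected range from 12000 nM to 120000 nM in this series.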

Compound 4, half-maximal inhibitory concentration: 3020 nM
Beside the measured number, compound 4's estimate is 13-fold (1.12 log units) above it, and the stated range ends above it.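

Among these compounds, compound 4 gives 3020 nM in this assay and compound 1 gives "not active" (no number reported) so no step from compound 1 to compound 4 can be read. No supporting data bear on this result.

The compounds shown leave open the size of the change from 4-chlorophenoxy to piperidin-1-yl.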